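This account rests on a few compounds, and the source may have more. Where it says the series, first, only, none or still open, it means among the compounds named here.

Compound 1, `COc1cc(-c2nnc(SCC(=O)c3ccc(Cl)cc3)n2N)cc(OC)c1OC`, is the reference point of the series. In a functional assay on HepG2 cells (Homo sapiens) for antiproliferative activity, read by MTT assay, with a stated time of 48 h (a lower number here means a stronger inhibitor, a higher number a weaker inhibitor), compound 1 reaches only the assay limit, > 100000 nM. Compound 2, `COc1cc(-c2nnc(SCC(=O)c3ccc(C(F)(F)F)cc3)n2N)cc(OC)c1OC`, likewise reaches only a limit in this assay, > 100000 nM. Among the measured compounds shown here, compound 3, `COc1cc(-c2nnc(SCC(=O)c3ccc(F)cc3)n2N)cc(OC)c1OC`, is the one member with a number in this assay, 90400 nM. Compound 1 thus stands at the limit together with compound 2 (the limit of > 100000 nM in this assay, at which 2 of the 3 values shown sit), and the measured steps are all small: an at least 1.1-fold lower number from compound 1 to compound 3 (0.04 log units; that floor lies within the scatter) and an at least 1.1-fold lower number from compound 2 to compound 3 (0.04 log units; that floor lies within the scatter), while a step that the two limits leave unreadable from compound 1 to compound 2.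

Compound 4, `COc1cccc(NC(=O)CSc2nnc(-c3cc(OC)c(OC)c(OC)c3)n2N)c1`, differs from compound 1 at the carbonyl carbon: (3-methoxyphenyl)amino in place of 4-chlorophenyl on a carbonyl carbon. For the measured compounds named here, none of the measured steps bears on this position; each of them swaps a substituent on an aromatic carbon and leaves the value at or near the limit. The step to compound 4 is of a different kind, so the measured set gives no directional guidance beyond the scatter. Compound 4 is therefore expected near 90000 nM, within a range of 20000 nM to 300000 nM. The expected step is an at least 1.1-fold lower number from compound 1 to compound 4 (0.04 log units; that floor lies within the scatter), with a fair chance that only a limit is reported.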

Compound 4, half-maximal inhibitory concentration: > 100000 nM
Compound 4 ended at the assay's limit; the forecaster's own chance of this, stated with the estimate: 55%; middle value at least 1.1-fold (0.04 log units) from the limit.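

In this assay, among the compounds shown here, compound 4 gives > 100000 nM, which is a limit, so the first change on the carbonyl carbon yields no measurable value. The steps to compound 4 from compound 1 and compound 2 cannot be read, leaving one readable step, an at least 1.1-fold higher number from compound 3 to compound 4 (0.04 log units; that floor lies within the scatter). Neither this position nor the aromatic substituent has so far produced a step beyond the scatter, and the series stays bunched at one end of the range: the limit of > 100000 nM in this assay, at which 3 of the 4 values shown sit.

Open, as far as these compounds go, is whether a morpholine or a plain alkylamine on the carbonyl carbon would give a value well clear of the limit. Also open, from the compounds shown here alone, is how much (3-methoxyphenyl)amino and 4-chlorophenyl differ, as limits on both sides hide the size and direction of that step.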